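Adding chlorine to a compound that shows no activity

The source may hold more compounds than are shown below. What is called first, only, known or untested is meant among the compounds shown, and "the series" means these compounds.

Compound 1 `CCCCC(Sc1ccc(OCCCOc2cccc(C)c2)cc1)C(=O)O` gives only a limit, not a number, in an assay for inhibition of Polyunsaturated fatty acid 5-lipoxygenase (Homo sapiens), read by HPLC, with a stated time of 10 min (a lower number here means a stronger inhibitor, a higher number a weaker inhibitor), at > 10000 nM. Compound 2 `CCCCC(Sc1ccc(OCCCOc2ccccc2OC)cc1)C(=O)O` likewise gives only a limit in this assay, at > 10000 nM. The step that the two limits leave unreadable from compound 1 to compound 2 cannot be sized because both values sit at the limit of > 10000 nM in this assay, at which 2 of the 2 values shown sit. Compound 3 `CCCCC(Sc1ccc(OCCCOc2ccc(Cl)cc2OC)cc1)C(=O)O` differs from compound 2 by chloro in place of hydrogen on an aromatic carbon. For the measured compounds named here, no measured step gives a readable size for such a change, so the expected step that the limit leaves unreadable from compound 2 to compound 3 carries no clear direction. Compound 3 is therefore estimated at 12000 nM, within 3000 nM to 50000 nM.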

Compound 3, half-maximal inhibitory concentration: > 10000 nM
Compound 3 was reported as a limit; the forecaster's own chance of this, stated with the estimate: 70%; the middle value does not contradict the limit.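

Compound 3 gives only a limit, as do compound 1 and compound 2, so no step among these three can be read: the limit of > 10000 nM in this assay, at which 3 of the 3 values shown sit.

As far as these compounds go, whether chloro in place of hydrogen on an aromatic carbon changes the result in this assay at all stays open.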